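The compounds below may be only part of what the source reports. "The series", "measured", "known", "first", "only" and "open" are said of these compounds alone.

Measured so far in a functional assay on Ehrlich cells (Mus musculus) for cytotoxicity, read by trypan blue exclusion, with a stated time of 2 h, tested at 50 ug/mL; on this read-out higher numbers stand for a stronger effect at the one concentration tested and lower numbers for a weaker effect:
compound 1 `COc1ccccc1C1C(C#N)=C(N)N(c2ccc(S(N)(=O)=O)cc2)C2=C1CCCC2` gives 50%;
compound 2 `COc1ccc(C2C(C#N)=C(N)N(c3ccc(S(N)(=O)=O)cc3)C3=C2CCCC3)cc1` gives 100%;
compound 3 `N#CC1=C(N)N(c2ccc(S(N)(=O)=O)cc2)C2=C(CCCC2)C1c1ccc([N+](=O)[O-])cc1` gives 10%.

Compound 3 stands lowest of the three measured numbers; its nearest neighbour is compound 1, with a number 40 percentage points lower from compound 1 to compound 3 (beyond the scatter), and its furthest is compound 2, with a number 90 percentage points lower from compound 2 to compound 3 (beyond the scatter).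

Compound 4 `N#CC1=C(N)N(c2ccc(S(N)(=O)=O)cc2)C2=C(CCCC2)C1c1cccs1` differs from compound 3 in one change: thiophen-2-yl in place of 4-nitrophenyl on a saturated ring carbon. For the measured compounds named here, no measured step brings in a thiophen-2-yl, so the steps that bear on it are those that exchanged the aryl group on the same saturated ring carbon: a number 40 percentage points lower from compound 1 to compound 3 (beyond the scatter), a number 90 percentage points lower from compound 2 to compound 3 (beyond the scatter) and a number 50 percentage points higher from compound 1 to compound 2 (beyond the scatter), all large. They show that this group moves the read-out strongly in either direction. Since the 4-nitrophenyl accompanies the lowest number, its removal is expected to raise the value, though the size is uncertain. The estimate for compound 4 is 50%, between 20% and 90%, an expected step of a number 40 percentage points higher from compound 3 to compound 4 (beyond the scatter).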

Compound 4, a percentage reported as activity, at one concentration (the size of the read-out at that concentration, not a potency): 10%
The estimate for compound 4 lay 40 percentage points above the measured number; the whole stated range lies above it.
By their numbers in this assay, from the lowest: compounds 3 and 4 (each within the scatter of the next); then compound 1; then compound 2.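

In this assay the step of no change at the digits printed from compound 3 to compound 4 (within the scatter) comes with thiophen-2-yl in place of 4-nitrophenyl on the saturated ring carbon, so the low number is not peculiar to the 4-nitrophenyl. Both methoxyphenyl compounds stand clear of the thiophen-2-yl, with a number 90 percentage points lower from compound 2 to compound 4 (beyond the scatter) and a number 40 percentage points lower from compound 1 to compound 4 (beyond the scatter) as the steps. No evidence available here accounts for these results. On these data alone, it remains open whether a 4-hydroxyphenyl or 4-aminophenyl on this carbon would keep the high number of compound 2 100% or whether a saturated group such as cyclohexyl would fall to the low end.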